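The source may report more compounds than this note shows. Statements on the series, on what has been measured and on what is new or still open speak of the compounds shown alone.

Compound 1 `O=C(Nc1ccccc1Br)C(Cl)Cl` gives 67900 nM in a functional assay on KB cells (Homo sapiens) for antiproliferative activity, read by MTT assay, with a stated time of 72 h; a higher number here means a weaker inhibitor, a lower number a stronger inhibitor. Compound 2 `O=C(Nc1ccccc1NC(=O)C(Cl)Cl)C(Cl)Cl` — in this assay compound 2 gives "not determined" (no result reported), so no result was obtained. Compound 3 `O=C(Nc1cccc(F)c1)C(Cl)Cl` — in this assay compound 3 gives "not determined" (no result reported), so no result was obtained.

Among the measured compounds shown here, compound 3 therefore stands nowhere on the numbers: it has no half-maximal inhibitory concentration in this assay, and the same holds for compound 2, so the only number available is that of compound 1, which is weak. Compound 4 `O=C(Nc1cccc(SC(F)(F)F)c1)C(Cl)Cl` differs from compound 3 in one place: (trifluoromethyl)sulfanyl in place of fluoro on an aromatic carbon. For the measured compounds named here, with no number for compound 3, no step in this assay can be sized or given a direction; the change is simply not anchored. Compound 4 is estimated to fall near 30000 nM, between 5000 nM and 150000 nM, in the weak range that compound 1 shows with 67900 nM.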

Compound 4, half-maximal inhibitory concentration: 4840 nM
Beside the measured number, compound 4's estimate is 6.2-fold (0.79 log units) above it, and the stated range ends above it.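

In this assay, among the compounds shown here, compound 3 has no single number, and no step to compound 4 can be read. The compounds shown leave open what (trifluoromethyl)sulfanyl in place of fluoro changes in this read-out. No evidence bears on this result.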